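Hydroxyl in place of branching on the nitrogen chain: expectation

The source may report more compounds than this note shows. Statements on the series, on what has been measured and on what is new or still open speak of the compounds shown alone.

Three compounds of the shared core have been run in an ADME assay on MT4 cells (Homo sapiens) for cytotoxicity, read by MTT assay, with a stated time of 5 days; on this read-out higher numbers stand for lower toxicity in this test and lower numbers for higher toxicity in this test. Compound 1 `CCN(c1ccnc(Nc2ccc(C#N)cc2)n1)c1c(F)cc(-c2ccc(C#N)cc2)cc1F` gives 105000 nM. Compound 2 `CC(C)N(c1ccnc(Nc2ccc(C#N)cc2)n1)c1c(F)cc(-c2ccc(C#N)cc2)cc1F` gives 172000 nM. Compound 3 `CC(C)CN(c1ccnc(Nc2ccc(C#N)cc2)n1)c1c(F)cc(-c2ccc(C#N)cc2)cc1F` gives 241000 nM. Compound 2 sits close to both of the others: the steps of a 1.6-fold higher number from compound 1 to compound 2 (0.21 log units; within the scatter) and a 1.4-fold higher number from compound 2 to compound 3 (0.15 log units; within the scatter) are each within the scatter, and only a 2.3-fold higher number from compound 1 to compound 3 (0.36 log units; beyond the scatter) is beyond it, and that one is modest.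

Compound 4 `CC(O)CN(c1ccnc(Nc2ccc(C#N)cc2)n1)c1c(F)cc(-c2ccc(C#N)cc2)cc1F` differs from compound 2 by 2-hydroxypropyl in place of isopropyl on a nitrogen on an aromatic ring. Among the compounds with values here, no measured step brings in an oxygen; the three measured changes only lengthen or branch the chain on that nitrogen, and the largest of them, a 2.3-fold higher number from compound 1 to compound 3 (0.36 log units; beyond the scatter), stays modest. The closest comparison by size of group, a 1.4-fold higher number from compound 2 to compound 3 (0.15 log units; within the scatter), lies within the scatter. The data therefore give no ground for a step beyond the scatter in either direction, and the expected step is a 1.2-fold higher number from compound 2 to compound 4 (0.07 log units; within the scatter). For compound 4 the estimate in this assay is 200000 nM, with a range from 100000 nM to 400000 nM.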

Compound 4, half-maximal cytotoxic concentration: 9800 nM
Compound 4: the middle estimate sits 20-fold (1.31 log units) above what was measured, outside the stated range (below it).
By their numbers in this assay, from the lowest: compound 4; then compounds 1, 2 and 3 (each within the scatter of the next, the first and the last beyond it).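

In this assay, the position on the nitrogen on an aromatic ring, which tolerated changes to the oxygen-free chain with modest steps at most, turns out to be sensitive to a hydroxyl on that chain. The change to 2-hydroxypropyl gives an 18-fold lower number from compound 2 to compound 4 (1.24 log units; beyond the scatter) and hydroxy in place of methyl gives a 25-fold lower number from compound 3 to compound 4 (1.39 log units; beyond the scatter), while the comparison with the remaining chain gives an 11-fold lower number from compound 1 to compound 4 (1.03 log units; beyond the scatter), so all three oxygen-free compounds show lower toxicity in this test than compound 4 by a large margin. Nothing available here accounts for this drop.

As far as these compounds go, whether the drop follows from the hydroxyl itself or from its place on the chain remains open. Also open, from the compounds shown here alone, is whether a methoxy group, an amine or a carboxylic acid on the same chain would give a step of similar size.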